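Amide nitrogen substituent: anilide versus benzyl

The source may hold more compounds than are shown below. What is called first, only, known or untested is meant among the compounds shown, and "the series" means these compounds.

Compound 1 `COc1ccc2c(=O)c(/C=C/C(=O)Nc3ccc(C)cc3)coc2c1` returns only a limit, > 100000 nM, in a functional assay on Huh-7 cells (Homo sapiens) for inhibition, read by MTT assay, with a stated time of 48 h; a lower number here means a stronger inhibitor, a higher number a weaker inhibitor. For the measured compounds named here, compound 2 `COc1ccc2c(=O)c(/C=C/C(=O)NCc3cccc(F)c3)coc2c1` gives 10100 nM in this assay, the only actual number in the set. The value of compound 1 sits at a limit (the limit of > 100000 nM in this assay, at which 1 of the 2 values shown sits). Going by the values given here, the single measured step, an at least 9.9-fold lower number from compound 1 to compound 2 (0.99 log units; beyond the scatter), shows that the group on the amide-type nitrogen moves the read-out over a wide range.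

Compound 3 `COc1ccc2c(=O)c(/C=C/C(=O)Nc3ccc(Cl)cc3)coc2c1` carries 4-chlorophenyl in place of 3-fluorobenzyl on an amide-type nitrogen. This returns the nitrogen substituent to the pattern of compound 1, a phenyl bonded directly to the amide-type nitrogen rather than a benzyl. Among the compounds with values here, the step of an at least 9.9-fold lower number from compound 1 to compound 2 (0.99 log units; beyond the scatter) is the only evidence bearing on this change and ran in the opposite direction, so a loss of comparable size is expected, its exact size uncertain because compound 1 gave only a limit. Compound 3 is therefore estimated at 60000 nM, within 15000 nM to 200000 nM. The expected step is a 5.9-fold higher number from compound 2 to compound 3 (0.77 log units; beyond the scatter), with a real chance of a limit only.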

Compound 3, half-maximal inhibitory concentration: 37100 nM
Beside the measured number, compound 3's estimate is 1.6-fold (0.21 log units) above it, within the range that was stated.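

With a second anilide measured, the loss on moving from a benzyl to a phenyl on the amide-type nitrogen no longer rests on a limit alone: in this assay the step is a 3.7-fold higher number from compound 2 to compound 3 (0.57 log units; beyond the scatter). Among the anilides, the group on the aromatic ring also matters, with chloro in place of methyl on an aromatic carbon giving an at least 2.6-fold lower number from compound 1 to compound 3 (0.43 log units; beyond the scatter). Compound 1 gives only a limit, so that step has no exact size: the limit of > 100000 nM in this assay, at which 1 of the 3 values shown sits.

From the compounds shown here alone, the step from 3-fluorobenzyl to 4-chlorophenyl changes both the benzyl-versus-phenyl attachment and the halogen at once, so the share of each in the loss remains open. Also open, going by these compounds, is how an amine or a carboxylic acid on the group at the amide-type nitrogen would read out.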